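Methoxy removal on the imide-nitrogen aryl group

This account rests on a few compounds, and the source may have more. Where it says the series, first, only, none or still open, it means among the compounds named here.

The series shares one core, carried by compound 1 `Cn1cc(C2=C(c3n[nH]c4ncccc34)C(=O)NC2=O)c2ccccc21`, compound 2 `Cn1cc(C2=C(c3nn(CCCn4ccnc4)c4ncccc34)C(=O)N(c3ccccc3)C2=O)c2ccccc21`, compound 3 `COc1ccc(N2C(=O)C(c3cn(C)c4ccccc34)=C(c3nn(CCCN4CCCCC4)c4ncccc34)C2=O)cc1` and the unmeasured compound 4 `Cn1cc(C2=C(c3nn(CCCN4CCCCC4)c4ncccc34)C(=O)N(c3ccccc3)C2=O)c2ccccc21`. In a functional assay on SMMC-7721 cells (Homo sapiens) for antiproliferative activity, read by MTT assay, with a stated time of 48 h (on this read-out lower numbers stand for stronger inhibition and higher numbers for weaker inhibition), compound 1 reaches only the limit of the assay, > 100000 nM, a boundary rather than a number; (the limit of > 100000 nM in this assay, at which 1 of the 3 values shown sits). In this assay compound 2 gives 34800 nM and compound 3 gives 1740 nM. Compound 3 therefore stands lowest of the two numbers, with compound 2 the nearest and a gap beyond the usual scatter between them; the pair differs in more than one place, so the two values are simply taken as they stand.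

Compound 4 differs from compound 3 in one place: hydrogen in place of methoxy on an aromatic carbon. Going by the values given here, no measured pair isolates this change, so the size of the step is unknown. The estimate is a modest weakening, a 2.3-fold higher number from compound 3 to compound 4 (0.36 log units; beyond the scatter), possibly no larger than the scatter. Compound 4 is expected to give about 4000 nM in this assay, within roughly 1200 nM to 13000 nM.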

Compound 4, half-maximal inhibitory concentration: 3050 nM
Compound 4: middle estimate off by 1.3-fold (0.12 log units), on the high side; measured number inside the range.
By their numbers in this assay, from the lowest: compounds 3 and 4 (each within the scatter of the next); then compound 2. At a limit, above all of these: compound 1.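

In this assay, the 4-methoxyphenyl to phenyl change gives a 1.8-fold higher number from compound 3 to compound 4 (0.24 log units; within the scatter) and so leaves the read-out unresolved: on the values shown, this position takes either group without a step beyond the scatter. The same new compound gives the series its first pair that isolates the group at the end of the chain, and an 11-fold lower number from compound 2 to compound 4 (1.06 log units; beyond the scatter) with phenyl held fixed, so piperidin-1-yl in place of 1H-imidazol-1-yl alone carries a large step. No measured property among the data bears on either step.

Open, going by these compounds, is whether the flat result at the aryl position extends beyond methoxy and hydrogen, for instance to a carboxylic acid or a fluorine atom on the same carbon. Also open, on these data alone, is whether the gain follows the piperidine ring specifically, or would also appear with morpholine, a dimethylamine or a shorter chain.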